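The source may hold more compounds than are shown below. What is called first, only, known or untested is meant among the compounds shown, and "the series" means these compounds.

Working notes on the series. In a functional assay on A549 cells (Homo sapiens) for cytotoxicity, read by MTT assay, with a stated time of 72 h (on this read-out lower numbers stand for stronger inhibition and higher numbers for weaker inhibition), compound 1 (`CCCCC(C)C[C@]1(CC)O[C@H]1[C@]1(CC)C=CC(=O)O1`) reads > 100000 nM as a limit of the assay and not a number. Compound 2 (`CCCCC(C)Cc1cc(CC)c(CC(=O)O)o1`) reads > 100000 nM and this too is only a limit. Among the compounds with values here, compound 3 (`CCCCC(C)CC(O)(/C=C(/CC)[C@@H](O)CC(=O)OC)CC`) reads 29300 nM and holds the only actual number in the set.

Compound 4 (`CCCCC(CC)CC(O)(/C=C(/CC)[C@@H](O)CC(=O)OC)CC`) departs from compound 3 by methyl in place of hydrogen on a saturated chain carbon, four bonds along the chain from a double-bonded chain carbon and an oxygen on a saturated carbon and the change is methyl in place of hydrogen on a saturated chain carbon, four bonds along the chain from a double-bonded chain carbon and an oxygen on a saturated carbon. Cut one bond further out, 1-methylpentyl becomes 1-ethylpentyl.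

Within the data shown here, the series offers no measured step between closely matched compounds, so the expectation rests on compound 3 at 29300 nM and on this single added carbon. In this assay no change beyond the scatter is expected, and the estimated step is a 1.2-fold lower number from compound 3 to compound 4 (0.07 log units; within the scatter) with no firm direction. For compound 4 the expected value is 25000 nM with an estimated range from 10000 nM to 60000 nM for the coming measurement.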

Compound 4, half-maximal inhibitory concentration: 23600 nM
Beside the measured number, compound 4's estimate is 1.1-fold (0.03 log units) above it; low and high end bracket the measured number.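

In this assay, the change from 1-methylpentyl to 1-ethylpentyl gives a 1.2-fold lower number from compound 3 to compound 4 (0.09 log units; within the scatter), so the added methyl on this saturated chain carbon brings no change beyond the scatter. Within the data shown here, this is the first matched step with a number on both sides, and it speaks for this single change only. Only compound 3 and compound 4 can be read against each other as numbers because the other values stop at a limit: the limit of > 100000 nM in this assay, at which 2 of the 4 values shown sit.

Going by these compounds, whether a longer chain such as hexyl, or an amine, in place of the ethyl of 1-ethylpentyl would move the number beyond the scatter remains open. Also open, on these data alone, is how a carboxylic acid in place of the methyl ester would read, with the rest of compound 4 unchanged.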